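Hydroxy-Dimethylphenyl in Place of Methoxyphenyl on the Core

The compounds below may be only part of what the source reports. "The series", "measured", "known", "first", "only" and "open" are said of these compounds alone.

Measured compounds:
compound 1 `CCCc1ccc(-c2cc(=O)c3c(o2)C(CC)(CC)C(=O)C(CC)=C3O)cc1`: 12.2 uM
compound 2 `CCC1=C(O)c2c(oc(-c3ccccc3OC)cc2=O)C(CC)(CC)C1=O`: 3.26 uM

In a functional assay on KBVIN cells (Homo sapiens) for antiproliferative activity, read by sulforhodamine B assay, with a stated time of 3 days (a higher number here means that more compound is needed for the effect, a lower number that less compound is needed), compound 1 gives 12.2 uM and compound 2 gives 3.26 uM, the lower of the two numbers. Among the compounds with values here, the single measured step, a 3.7-fold lower number from compound 1 to compound 2 (0.57 log units; beyond the scatter), shows that swapping the aromatic ring on the shared core moves the number beyond the scatter. Compound 3 `CCC1=C(O)c2c(oc(-c3cc(C)c(O)c(C)c3)cc2=O)C(CC)(CC)C1=O` carries the change (4-hydroxy-3,5-dimethylphenyl in place of 2-methoxyphenyl on an aromatic carbon). Within the data shown here, that step is the only guide, and it does not say which way a 4-hydroxy-3,5-dimethylphenyl will move the number. Compound 3 is thus expected to show a modest rise, a 1.7-fold higher number from compound 2 to compound 3 (0.23 log units; within the scatter). Compound 3 is estimated at 5.5 uM, between 1.8 uM and 17 uM.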

Compound 3, concentration for half-maximal effect: 8.9 uM
Beside the measured number, compound 3's estimate is 1.6-fold (0.21 log units) below it; low and high end bracket the measured number.
By their numbers in this assay, from the lowest: compound 2; then compounds 3 and 1 (each within the scatter of the next).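

In this assay the aromatic ring on the shared core matters again: 4-hydroxy-3,5-dimethylphenyl in place of 2-methoxyphenyl gives a 2.7-fold higher number from compound 2 to compound 3 (0.44 log units; beyond the scatter) and so gives back part of the earlier gain. In place of 4-propylphenyl, the same group gives a 1.4-fold lower number from compound 1 to compound 3 (0.14 log units; within the scatter) and these two rings cannot be told apart here. Nothing available explains either step. From the compounds shown here alone, it remains open how far the number would move with an amine or a carboxylic acid on the aromatic ring, or with a chain longer than propyl.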